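The compounds below may be only part of what the source reports. "The series", "measured", "known", "first", "only" and "open" are said of these compounds alone.

Three compounds with a shared core anchor this comparison. Compound 1 `O=C(N[C@@H]1CC=CCN(O)C1=O)c1ccc(Oc2ccc(Cl)cc2)cc1` gives 5090 nM in an assay on isolated protein for inhibition of matrix metalloproteinase-9 (Homo sapiens), read by fluorescence, with stated times of 1 h and 15 min; on this read-out higher numbers stand for weaker inhibition and lower numbers for stronger inhibition. Compound 2 `O=C1[C@H](NS(=O)(=O)c2ccc(Oc3ccccc3)cc2)CC=CCN1O` gives 2 nM in this assay, and compound 3 `COc1ccc(Oc2ccc(S(=O)(=O)N[C@@H]3CC=CCN(O)C3=O)cc2)cc1` gives 1 nM. On these numbers compound 3 sits at the low end: its value and that of compound 2 fall within the scatter of each other, while compound 1 lies far higher, a gap well beyond the scatter.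

The step to compound 4 `O=C1[C@H](NS(=O)(=O)c2ccc(Oc3ccc(C(F)(F)F)cc3)cc2)CC=CCN1O` is trifluoromethyl in place of methoxy on an aromatic carbon. For the measured compounds named here, only one measured step touches the same ring: a 2.0-fold lower number from compound 2 to compound 3 (0.30 log units; within the scatter), which changed nothing beyond the scatter. Going by the values given here, no measured step exchanges a methoxy for a trifluoromethyl, so the direction of any effect is unknown. Among the compounds with values here, with the one nearby step flat, the expected change in this assay is a 1.5-fold higher number from compound 3 to compound 4 (0.18 log units; within the scatter), none beyond the scatter. Compound 4 is therefore estimated at 1.5 nM, with a range from 0.4 nM to 6 nM.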

Compound 4, half-maximal inhibitory concentration: 2 nM
The estimate for compound 4 lay 1.3-fold (0.12 log units) below the measured number, within the range that was stated.
By their numbers in this assay, from the lowest: compounds 3, 2 and 4 (each within the scatter of the next); then compound 1.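

In this assay, trifluoromethyl in place of methoxy gave a 2.0-fold higher number from compound 3 to compound 4 (0.30 log units; within the scatter), and trifluoromethyl in place of hydrogen gave no change at the digits printed from compound 2 to compound 4 (within the scatter). Where the earlier compounds compared only hydrogen and methoxy at this place on the aromatic ring, para to a large group, a third group now shows the same result: compound 2, compound 3 and compound 4 all lie within the scatter of one another, so this read-out does not separate the three groups. Nothing available explains why they read alike.

The compounds shown leave open whether an amine, a carboxylic acid or a longer chain at this place would also stay within the scatter. They also leave open whether these three groups would read alike against any other protein.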